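A few compounds are considered here, and "the series" means these few. Any claim that something is new, unique, unknown or untested is made for them only; others in the source may bear on it.

Measured in a functional assay on KB cells (Homo sapiens) for antiproliferative activity, read by MTT assay, with a stated time of 72 h; on this read-out higher numbers stand for weaker inhibition and lower numbers for stronger inhibition:
- compound 1 `CCOC(=O)c1cc(-c2cc(OC)c(OC)c(OC)c2)c(-c2ccc3ccccc3c2)s1`: 5890 nM
- compound 2 `COc1ccc(-c2sc(C(=O)O)cc2-c2cc(OC)c(OC)c(OC)c2)cc1`: 10400 nM
- compound 3 `COc1cc(-c2cc(C(=O)O)sc2-c2cccc(Br)c2)cc(OC)c1OC`: 32300 nM

Of these three, compound 3 carries the highest number, 32300 nM, and so shows the weakest inhibition in this assay. Compound 4 `COc1cc(-c2cc(C(=O)O)sc2-c2ccc3ccccc3c2)cc(OC)c1OC` has not yet been measured. It differs from compound 3 at a single place: naphthalen-2-yl in place of 3-bromophenyl on an aromatic carbon. The group sits on an aromatic carbon of a five-membered aromatic ring with 1 sulfur, next to the ring sulfur.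

For the measured compounds named here, only one measured step bears directly on this change. Exchanging 4-methoxyphenyl for 3-bromophenyl on that carbon gave a 3.1-fold higher number from compound 2 to compound 3 (0.49 log units; beyond the scatter), so the group at this place does move the number, though modestly. Going by the values given here, compound 1 also carries naphthalen-2-yl and reads 5890 nM, but it has an ethyl ester instead of the carboxy group, and no measured step isolates that difference. Taken together, these data point to a modest step towards a lower number in this assay, similar in size to the one measured. The expected step is a 2.3-fold lower number from compound 3 to compound 4 (0.36 log units; beyond the scatter). For compound 4 the estimated value is 14000 nM, with an expected range from 5000 nM to 35000 nM.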

Compound 4, half-maximal inhibitory concentration: 5640 nM
Beside the measured number, compound 4's estimate is 2.5-fold (0.39 log units) above it, and the stated range covers the measured number.
By their numbers in this assay, from the lowest: compounds 4, 1 and 2 (each within the scatter of the next); then compound 3.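

In this assay the aromatic carbon next to the ring sulfur proves more responsive than the earlier single step suggested: naphthalen-2-yl in place of 3-bromophenyl gives a larger change (a 5.7-fold lower number from compound 3 to compound 4 (0.76 log units; beyond the scatter)) than the earlier exchange of 4-methoxyphenyl for 3-bromophenyl (a 3.1-fold higher number from compound 2 to compound 3 (0.49 log units; beyond the scatter)). Naphthalen-2-yl and 4-methoxyphenyl cannot be told apart at this carbon (a 1.8-fold lower number from compound 2 to compound 4 (0.27 log units; within the scatter)), so among the three carboxy compounds shown, only the 3-bromophenyl of compound 3 stands apart from the other two. With naphthalen-2-yl held constant, hydrogen in place of ethyl on the oxygen next to a carbonyl group also leaves the number within the scatter (a 1.0-fold lower number from compound 1 to compound 4 (0.02 log units; within the scatter)), so the ethyl ester and the carboxy group cannot be separated on this one pair.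

Nothing available explains why the two larger changes at this carbon differ in size. On these data alone, it remains open how a phenyl bearing an amine or a nitrile, or an amide in place of the carboxy group, would read in this assay, and whether the ethyl ester would match the carboxy group with 3-bromophenyl or 4-methoxyphenyl at this carbon.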